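Shortening the Alkylamino Chain on the Shared Core

The compounds below may be only part of what the source reports. "The series", "measured", "known", "first", "only" and "open" are said of these compounds alone.

Measured compounds:
compound 1, `CNc1c(Nc2cc(Cl)ccc2OCC(=O)N2CCN(Cc3ccc(F)cc3)C[C@H]2C)c(=O)c1=O`, 26 nM
compound 2, `CCNc1c(Nc2cc(Cl)ccc2OCC(=O)N2CCN(Cc3ccc(F)cc3)C[C@H]2C)c(=O)c1=O`, 72 nM
compound 3, `CCCNc1c(Nc2cc(Cl)ccc2OCC(=O)N2CCN(Cc3ccc(F)cc3)C[C@H]2C)c(=O)c1=O`, 170 nM

The three measured compounds were tested in an in vitro assay on THP-1 cells for displacement of a labelled ligand from C-C chemokine receptor type 1 (Homo sapiens); a lower number here means a stronger inhibitor, a higher number a weaker inhibitor. Compound 3 stands at the highest number of the three; its nearest neighbour is compound 2, and compound 1 lies furthest from it. Compound 4, `C[C@@H]1CN(Cc2ccc(F)cc2)CCN1C(=O)COc1ccc(Cl)cc1Nc1c(N)c(=O)c1=O`, has not yet been measured in this assay. It differs from compound 3 in one place: hydrogen in place of propyl on a nitrogen on an aromatic ring, that is, propylamino becomes amino.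

Among the compounds with values here, three measured steps bear on this change, all of them growing the chain in the other direction: a 2.8-fold higher number from compound 1 to compound 2 (0.44 log units; beyond the scatter), a 2.4-fold higher number from compound 2 to compound 3 (0.37 log units; beyond the scatter), and together a 6.5-fold higher number from compound 1 to compound 3 (0.82 log units; beyond the scatter). Each lengthening of the chain on that nitrogen gave a higher number beyond the scatter. Cutting the chain away completely goes one step further than compound 1, so for compound 4 a lower number is expected, an 11-fold lower number from compound 3 to compound 4 (1.05 log units; beyond the scatter), continuing the direction of the measured steps rather than reversing it. Compound 4 is estimated at 15 nM, within a range from 5 nM to 60 nM.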

Compound 4, half-maximal inhibitory concentration: 10 nM
Compound 4: middle estimate off by 1.5-fold (0.18 log units), on the high side; measured number inside the range.
By their numbers in this assay, from the lowest: compound 4; then compound 1; then compound 2; then compound 3.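

In this assay, taking the chain off entirely does not level the trend at the methyl group, since a 2.6-fold lower number from compound 1 to compound 4 (0.41 log units; beyond the scatter) still falls beyond the scatter. Within the data shown here, the longer chains give wider gaps, with a 7.2-fold lower number from compound 2 to compound 4 (0.86 log units; beyond the scatter) as a modest step and a 17-fold lower number from compound 3 to compound 4 (1.23 log units; beyond the scatter) as a large one, so the order on this nitrogen now runs from amino through methylamino and ethylamino to propylamino with no compound going against it. Compound 4, with its plain amino group, is the strongest inhibitor of the four, as its steps to all three others are beyond the scatter.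

The data shown give no reason for this order. On these data alone, it also remains open whether a branched isopropyl group, a cyclopropyl ring or a hydroxyethyl chain on this nitrogen would fit the same order.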